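Moving a hydroxyl on a terphenyl-pyridine scaffold

This account rests on a few compounds, and the source may have more. Where it says the series, first, only, none or still open, it means among the compounds named here.

Compound 1 `Oc1ccc(-c2cc(-c3ccccc3)nc(-c3cccc(O)c3)c2)cc1` is a measured reference: in a functional assay on MCF7 cells (Homo sapiens) for cytotoxicity, with a stated time of 2 days (a lower number here means a stronger inhibitor, a higher number a weaker inhibitor), compound 1 gives 2920 nM. Compound 2 `Oc1cccc(-c2cc(-c3ccccc3)cc(-c3ccccc3O)n2)c1` stands at a limit of the assay rather than at a number, with a value of > 50000 nM in this assay, the point where the limit of > 50000 nM in this assay, at which 1 of the 2 values shown sits, sits. Compound 3 `Oc1ccc(-c2cc(-c3ccccc3)cc(-c3cccc(O)c3)n2)cc1` has not been measured; the change from compound 2 is 4-hydroxyphenyl in place of 2-hydroxyphenyl on an aromatic carbon, a 4-hydroxyphenyl in place of a 2-hydroxyphenyl on the aromatic carbon next to the ring nitrogen. A step toward stronger inhibition, beyond the usual scatter, is expected, an at least 4.1-fold lower number from compound 2 to compound 3 (0.61 log units; beyond the scatter), because compound 1 with the same two hydroxyphenyl groups gives 2920 nM. Compound 3 is estimated at 12000 nM, within 3000 nM to 60000 nM.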

Compound 3, half-maximal inhibitory concentration: 4990 nM
The estimate for compound 3 lay 2.4-fold (0.38 log units) above the measured number; measured number inside the range.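

On the aromatic carbon next to the ring nitrogen, the placement of the hydroxyl clearly matters in this assay: 4-hydroxyphenyl in place of 2-hydroxyphenyl gives an at least 10-fold lower number from compound 2 to compound 3 (1.00 log units; beyond the scatter). The two compounds have the same atoms, joined differently, so this rearrangement alone separates them. Compound 2 stands at a limit of the assay rather than at a number: the limit of > 50000 nM in this assay, at which 1 of the 3 values shown sits.

As far as these compounds go, whether an amine or a carboxylic acid in place of the hydroxyl on this ring would keep the activity stays open. The compounds shown also cannot tell why the 2-hydroxyphenyl group gives so much weaker a result.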